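Swapping the side chain on compound 2

A few compounds are considered here, and "the series" means these few. Any claim that something is new, unique, unknown or untested is made for them only; others in the source may bear on it.

Compound 1 `O=C1c2c[n+]([O-])c3ccccc3c2C(=O)c2c1c1ccccc1n2CCCCn1ccnc1`: 130 nM
Compound 2 `O=C1c2c[n+]([O-])c3ccccc3c2C(=O)c2c1c1ccccc1n2CCN1CCCCC1`: 620 nM

Within the data shown here, in a functional assay on MCF7 cells (Homo sapiens) for cytotoxicity, read by MTT assay, with a stated time of 72 h (on this read-out higher numbers stand for weaker inhibition and lower numbers for stronger inhibition), compound 2 at 620 nM is the higher of the two numbers so far. Compound 3 `O=C1c2c[n+]([O-])c3ccccc3c2C(=O)c2c1c1ccccc1n2Cc1cn(C[C@@H](O)CO)nn1` differs from it on a saturated chain carbon bound to an aromatic nitrogen: 1-(2,3-dihydroxypropyl)-1H-1,2,3-triazol-4-yl in place of (piperidin-1-yl)methyl on a saturated chain carbon bound to an aromatic nitrogen is the whole change. Among the measured compounds shown here, the only measured step is a 4.8-fold higher number from compound 1 to compound 2 (0.68 log units; beyond the scatter) and it involved other groups, so it shows that side-chain swaps can shift the number but gives no direction here. In this assay no step beyond the scatter is therefore expected, though a modest one either way remains possible. The estimated change is a 1.4-fold lower number from compound 2 to compound 3 (0.14 log units; within the scatter) and would be small. Compound 3 is expected at 450 nM with an estimated range from 130 nM to 1500 nM on this read-out.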

Compound 3, half-maximal inhibitory concentration: 600 nM
The estimate for compound 3 lay 1.3-fold (0.12 log units) below the measured number, within the range that was stated.
By their numbers in this assay, from the lowest: compound 1; then compounds 3 and 2 (each within the scatter of the next).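

In this assay, 1-(2,3-dihydroxypropyl)-1H-1,2,3-triazol-4-yl and (piperidin-1-yl)methyl cannot be told apart at this position, with a 1.0-fold lower number from compound 2 to compound 3 (0.01 log units; within the scatter), although the two groups differ in ring type and hydrogen-bond donors. Compound 1 stands apart, with a 4.6-fold higher number from compound 1 to compound 3 (0.66 log units; beyond the scatter), so among these three only the 3-(1H-imidazol-1-yl)propyl group goes with a clearly lower number. No available measurement explains these numbers. Still open, as far as these compounds go, is whether the 1H-imidazol-1-yl ring or the longer chain of compound 1 matters more, and how a carboxylic acid on the chain would compare.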